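Swapping Trifluoromethyl for Hydrogen on Compound 3

The source may report more compounds than this note shows. Statements on the series, on what has been measured and on what is new or still open speak of the compounds shown alone.

In a functional assay on SW620/5-FU cells (Homo sapiens) for cytotoxicity, read by MTT assay, with a stated time of 48 h, in the presence of a further agent that is not named here (on this read-out higher numbers stand for an effect only at larger amounts of compound and lower numbers for an effect already at smaller amounts), compound 3 `Cn1nc(C(F)(F)F)c2c(-c3ccccc3)cc(NNC(=O)Nc3cc(Cl)nc(Cl)c3)nc21` gives 13100 nM. Compound 1 `COc1ccc(-c2cc(NNC(=O)Nc3cc(Cl)nc(Cl)c3)nc3c2cnn3C)cc1` gives 18500 nM, within the usual scatter of compound 3. Compound 2 `COc1cc(NC(=O)NNc2cc(-c3ccccc3)c3cnn(C)c3n2)cc(Cl)n1` gives 28700 nM, higher than compound 3 and beyond that scatter, so compound 3 sits with compound 1 at the lower end of these numbers. Compound 4 `Cn1ncc2c(-c3ccccc3)cc(NNC(=O)Nc3cc(Cl)nc(Cl)c3)nc21` differs from compound 3 in one place: hydrogen in place of trifluoromethyl on an aromatic carbon. Going by the values given here, no measured pair isolates this change. Compound 1 also lacks trifluoromethyl, though it differs elsewhere too, and its value of 18500 nM suggests no step beyond the scatter. The expected step is a 1.4-fold higher number from compound 3 to compound 4 (0.14 log units; within the scatter). The estimated value for compound 4 is 18000 nM, with an expected range of 9000 nM to 36000 nM.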

Compound 4, half-maximal effective concentration: 76900 nM
Estimate against measurement, compound 4: 4.3-fold (0.63 log units) below, outside the stated range (above it).
By their numbers in this assay, from the lowest: compounds 3, 1 and 2 (each within the scatter of the next, the first and the last beyond it); then compound 4.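

In this assay, hydrogen in place of trifluoromethyl gives a 5.9-fold higher number from compound 3 to compound 4 (0.77 log units; beyond the scatter), the first direct sign that this aromatic carbon of the five-membered ring affects the read-out. Methoxy matters too, at two other places: chloro in its place gives a 2.7-fold higher number from compound 2 to compound 4 (0.43 log units; beyond the scatter), and hydrogen in its place gives a 4.2-fold higher number from compound 1 to compound 4 (0.62 log units; beyond the scatter). Nothing measured here explains these steps. On these data alone, whether a methyl group or a nitrile on that same carbon would keep the number low remains open. So does whether such a group would combine with methoxy to lower it further.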